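Removing one methyl from a weak antiproliferative compound

The compounds below may be only part of what the source reports. "The series", "measured", "known", "first", "only" and "open" are said of these compounds alone.

Compound 1 `COc1ccc(C(=O)/C=C\Nc2ccc(-c3nc4cc(OC)c(OC)c(OC)c4s3)cc2)cc1O` gives 18100 nM in a functional assay on MDA-MB-231 cells (Homo sapiens) for antiproliferative activity, read by sulforhodamine B assay, with a stated time of 48 h; on this read-out lower numbers stand for stronger inhibition and higher numbers for weaker inhibition
Compound 2 `COc1cc(C(=O)/C=C\Nc2ccc(-c3nc4cc(OC)c(OC)c(OC)c4s3)cc2C)cc(OC)c1OC` gives 12900 nM in this assay

Compound 2 at 12900 nM has the lower of the two numbers, but its gap to compound 1 lies within the scatter, so the pair cannot be ranked. Compound 3 `COc1cc(C(=O)/C=C\Nc2ccc(-c3nc4cc(OC)c(OC)c(OC)c4s3)cc2)cc(OC)c1OC` has not yet been measured in this assay and differs from compound 2 by one change: hydrogen in place of methyl on an aromatic carbon. Among the measured compounds shown here, the measured compounds differ in more than one place, so no measured step shows what this change does. The estimated step of a 1.1-fold lower number from compound 2 to compound 3 (0.03 log units; within the scatter) is expected to stay within the scatter, with no clear direction. Compound 3 is expected at 12000 nM with 4000 nM to 35000 nM as the estimated range around it.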

Compound 3, half-maximal inhibitory concentration: 16500 nM
Compound 3: the middle estimate sits 1.4-fold (0.14 log units) below what was measured, within the range that was stated.
By their numbers in this assay, from the lowest: compounds 2, 3 and 1 (each within the scatter of the next).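

Compound 3 joins both earlier compounds through single changes, which the two of them could not offer on their own. In this assay, hydrogen in place of methyl on an aromatic carbon, ortho to a large group and meta to a large group, gives a 1.3-fold higher number from compound 2 to compound 3 (0.11 log units; within the scatter), and 3,4,5-trimethoxyphenyl in place of 3-hydroxy-4-methoxyphenyl on a carbonyl carbon gives a 1.1-fold lower number from compound 1 to compound 3 (0.04 log units; within the scatter), so neither change can be told from repeat measurement at these numbers. Nothing on hand bears on the reason for these results.

Only methyl and hydrogen are shown on this aromatic carbon, so it remains open whether an amine, a carboxylic acid or a longer chain there would shift the number beyond the scatter. From the compounds shown here alone, whether either change would matter on a more potent compound also remains open.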